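Swapping a methoxyphenyl for a furan in a weak series

The compounds below may be only part of what the source reports. "The series", "measured", "known", "first", "only" and "open" are said of these compounds alone.

Compound 1 `CN1CCN(c2ccc(Nc3ncc(Cl)c(NCc4ccc(C(F)(F)F)cc4)n3)nc2)CC1` in a functional assay on Jurkat cells (Homo sapiens) for inhibition, read by CCK-8 assay, with a stated time of 48 h (on this read-out lower numbers stand for stronger inhibition of growth and higher numbers for weaker inhibition of growth), gives 7960 nM
Compound 2 `CN1CCN(c2ccc(Nc3ncc(Cl)c(NCc4ccc(F)cc4)n3)nc2)CC1` gives > 100000 nM (a limit of the assay, not a number)
Compound 3 `COc1cccc(CNc2nc(Nc3ccc(N4CCN(C)CC4)cn3)ncc2Cl)c1` gives 73400 nM

Of the two true numbers, compound 3 holds the higher one, with a 9.2-fold higher number from compound 1 to compound 3 (0.96 log units; beyond the scatter) as the gap. The entry for compound 2 is only a limit.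

Going by the values given here, compound 4 `CN1CCN(c2ccc(Nc3ncc(Cl)c(NCc4ccco4)n3)nc2)CC1` keeps the shared core and carries furan-2-yl in place of 3-methoxyphenyl on a saturated chain carbon bound to a nitrogen on an aromatic ring as the only change.

Two other measured steps also exchange the group at this place. One is the gap already given, which sets compound 1 apart. The other is an at least 1.3-fold lower number from compound 2 to compound 3 (0.13 log units; that floor lies within the scatter) and gives no clear separation. The step of an at least 12-fold higher number from compound 1 to compound 2 (1.09 log units; beyond the scatter) also sets compound 1 apart. Compound 4 has no trifluoromethyl group, so it is expected to resemble compound 3 and compound 2 rather than compound 1.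

The expected change is a 1.0-fold lower number from compound 3 to compound 4 (0.02 log units; within the scatter) in this assay and no step beyond the scatter is foreseen in either direction. Compound 4 is estimated at 70000 nM in this test of growth. The estimated range for compound 4 runs from 20000 nM to 100000 nM. A result that is only a limit would not surprise.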

Compound 4, concentration for 50% growth inhibition: > 100000 nM
Compound 4 gave a limit, no number; the forecaster's own chance of this, stated with the estimate: 35%; middle value at least 1.4-fold (0.15 log units) away from the limit.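

Compound 4 sits at a limit of this assay, > 100000 nM, which is a bound and not a number. At this place on a saturated chain carbon bound to a nitrogen on an aromatic ring, the swap to a five-membered aromatic ring with 1 hetero atom gives an at least 1.3-fold higher number from compound 3 to compound 4 (0.13 log units; that floor lies within the scatter), so furan-2-yl cannot be told apart from 3-methoxyphenyl, while an at least 12-fold higher number from compound 1 to compound 4 (1.09 log units; beyond the scatter) shows that this new ring type also stays clearly short of the 4-(trifluoromethyl)phenyl compound. The step between the other two limit-bound compounds, compound 2 and compound 4, cannot be read because neither has a true number: the limit of > 100000 nM in this assay, at which 2 of the 4 values shown sit.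

Compound 1 alone carries trifluoromethyl, and at 7960 nM it is still a weak growth inhibitor, so the data do not tell whether that group itself or simply a substituted phenyl ring of that kind sets it apart. A phenyl ring bearing a nitrile, a carboxylic acid or an amine in place of trifluoromethyl, or a longer chain in place of the single saturated carbon, remains untested by the compounds shown here.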